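The compounds below may be only part of what the source reports. "The series", "measured", "known", "first", "only" and "open" are said of these compounds alone.

Working notes on the series in an ADME assay on L1210/0 cells (Mus musculus) for cytotoxicity, with a stated time of 48 h; on this read-out lower numbers stand for stronger inhibition and higher numbers for weaker inhibition: compound 1 `O=c1[nH]c(=O)n([C@H]2C[C@H](O)[C@@H](CO)O2)cc1CO` gives 9180 nM, compound 2 `O=c1[nH]c(=O)n([C@H]2C[C@H](O)[C@@H](CO)O2)cc1[N+](=O)[O-]` gives 130 nM, and compound 3 `C=C(Cl)c1cn([C@H]2C[C@H](O)[C@@H](CO)O2)c(=O)[nH]c1=O` gives 1660 nM, the middle of the three numbers. Next comes compound 4 `O=C(CI)NCc1cn([C@H]2C[C@H](O)[C@@H](CO)O2)c(=O)[nH]c1=O`, with (((iodomethyl)carbonyl)amino)methyl in place of 1-chloroethenyl on an aromatic carbon. The measured steps at this same place are a 71-fold lower number from compound 1 to compound 2 (1.85 log units; beyond the scatter), a 5.5-fold lower number from compound 1 to compound 3 (0.74 log units; beyond the scatter) and a 13-fold higher number from compound 2 to compound 3 (1.11 log units; beyond the scatter). They range from modest to large and run in both directions, but none involves the entering group, so they fix no direction. A step within the scatter is therefore expected, with wide margins. The estimated step is a 1.5-fold higher number from compound 3 to compound 4 (0.18 log units; within the scatter). For compound 4 the expected value is 2500 nM, with an estimated range of 300 nM to 20000 nM.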

Compound 4, half-maximal inhibitory concentration: 107000 nM
Beside the measured number, compound 4's estimate is 43-fold (1.63 log units) below it, and the stated range ends below it.
By their numbers in this assay, from the lowest: compound 2; then compound 3; then compound 1; then compound 4.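

In this assay, (((iodomethyl)carbonyl)amino)methyl in place of 1-chloroethenyl gives a 64-fold higher number from compound 3 to compound 4 (1.81 log units; beyond the scatter), and in place of nitro it gives an 820-fold higher number from compound 2 to compound 4 (2.92 log units; beyond the scatter). On the saturated chain carbon bound to the aromatic carbon, ((iodomethyl)carbonyl)amino in place of hydroxy gives a 12-fold higher number from compound 1 to compound 4 (1.07 log units; beyond the scatter), so this position also admits a group with a higher number than hydroxymethyl. No available evidence accounts for these steps.

The compounds shown do not separate the iodine from the amide link as the part that goes with these steps. An aminomethyl group or an (acetylamino)methyl group at this position would bear on that.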